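From Methyl to Pentyl on the Shared Core

The compounds below may be only part of what the source reports. "The series", "measured", "known", "first", "only" and "open" are said of these compounds alone.

Among the compounds with values here, compound 1 `Cc1nnc2nnc(N3CCCC3)nn12` is the only compound here with a numeric result. In a functional assay on BeWo cells (Homo sapiens) for cytotoxicity, read by MTT assay, with a stated time of 72 h (on this read-out higher numbers stand for weaker inhibition and lower numbers for stronger inhibition), compound 1 gives 5360 nM. Compound 2 `c1ccc(-c2nnc3nnc(N4CCCC4)n3n2)cc1` gives > 100000 nM, which is a limit of the assay and not a number. Beyond that, only the limit of > 100000 nM in this assay, at which 1 of the 2 values shown sits, is known. Compound 3 `CCCCCc1nnc2nnc(N3CCCC3)nn12` differs from compound 1 by butyl in place of hydrogen on a saturated chain carbon bound to an aromatic carbon. Within the data shown here, no measured pair shows what a longer chain does, so the step from compound 1 to compound 3 is expected to be a 1.5-fold lower number from compound 1 to compound 3 (0.19 log units; within the scatter), within the scatter. Compound 3 is therefore estimated at 3500 nM, likely between 600 nM and 25000 nM.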

Compound 3, half-maximal inhibitory concentration: 27900 nM
For compound 3 the middle estimate is 8.0-fold (0.90 log units) below the measured one; the measured number lies above the stated range.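

In this assay, this position on the shared core does respond to the chain it carries: the change from methyl to pentyl gives a 5.2-fold higher number from compound 1 to compound 3 (0.72 log units; beyond the scatter), which means weaker inhibition. Within the data shown here, the earlier compounds offered no measured step at this place, so this is the first sized change here, and it lies beyond the usual scatter.

From the compounds shown here alone, whether inhibition weakens gradually along the chain stays open, as a propyl chain or a chain ending in an amine would be needed to tell. Compound 2 remains a limit and not a number: the limit of > 100000 nM in this assay, at which 1 of the 3 values shown sits.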